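A few compounds are considered here, and "the series" means these few. Any claim that something is new, unique, unknown or untested is made for them only; others in the source may bear on it.

Measured compounds:
- compound 1, `CN(C)CCNc1ccnc2cc(OCc3ccc(F)cc3)ccc12`: 890 nM
- compound 2, `CCCCOc1ccc2c(Cl)ccnc2c1`: 4130 nM

Two compounds carry a number in a functional assay on SK-OV-3 cells (Homo sapiens) for cytotoxicity, read by MTT assay, with a stated time of 48 h; on this read-out higher numbers stand for weaker inhibition and lower numbers for stronger inhibition. Compound 1, `CN(C)CCNc1ccnc2cc(OCc3ccc(F)cc3)ccc12`, gives 890 nM in this assay, the lower of the two values. Compound 2, `CCCCOc1ccc2c(Cl)ccnc2c1`, gives 4130 nM in this assay, a higher number, and the gap between compound 2 and compound 1 lies beyond the usual scatter. Within the data shown here, no step between compounds that differ in a single place has been measured, so the pair of numbers shows only that compound 1 sits lower than compound 2; the two structures differ in several places at once.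

The next compound, compound 3, `CN(C)CCNc1ccnc2cc(OCc3ccccc3)ccc12`, has not yet been measured. Relative to compound 1 the change is hydrogen in place of fluoro on an aromatic carbon, a hydrogen in place of fluoro on an aromatic carbon. Nothing measured here speaks to this particular change, so the expectation rests on the smallness of the change itself: a step in this assay from compound 1 to compound 3 of a 1.2-fold higher number from compound 1 to compound 3 (0.09 log units; within the scatter) is expected, that is, no shift beyond the scatter, with a slight lean toward a higher number. For compound 3 the estimate in this assay is 1100 nM, in the range 500 nM to 2500 nM.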

Compound 3, half-maximal inhibitory concentration: 2350 nM
Compound 3: the middle estimate sits 2.1-fold (0.33 log units) below what was measured; low and high end bracket the measured number.
By their numbers in this assay, from the lowest: compound 1; then compounds 3 and 2 (each within the scatter of the next).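

In this assay, among these compounds, the change from 4-fluorobenzyl to benzyl gives a 2.6-fold higher number from compound 1 to compound 3 (0.42 log units; beyond the scatter), the first step in this set that can be tied to a single place. It shows that this position, an aromatic carbon para to a large group, is not silent: with the rest of the structure held fixed, exchanging one fluorine atom for hydrogen moves the number beyond the scatter, and the fluoro compound, compound 1, holds the lower number. No measurement at hand accounts for this shift, so it stands as an observation without an explanation.

The compounds shown leave open whether the lower number belongs to fluoro alone or would also come with chloro, methyl, methoxy or trifluoromethyl at the same place. They also leave open whether a step of this size would persist if the dimethylamino group at the end of the side chain gave way to a morpholine or a piperidine, or if that side chain were replaced by a longer chain.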